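The compounds below may be only part of what the source reports. "The series", "measured", "known", "first", "only" and "open" are said of these compounds alone.

Measured in a functional assay on HL-60 cells (Homo sapiens) for cytotoxicity, read by WST assay, with a stated time of 48 h; on this read-out lower numbers stand for an effect already at smaller amounts and higher numbers for an effect only at larger amounts of compound:
- compound 1 `O=C1OC[C@H](Cc2cccc(F)c2)[C@H]1Cc1ccc(Cl)c(Cl)c1`: 14000 nM
- compound 2 `COc1ccc(C[C@H]2COC(=O)[C@@H]2Cc2ccc(Cl)c(Cl)c2)cc1`: 37000 nM
- compound 3 `Cc1ccc(C[C@H]2COC(=O)[C@@H]2Cc2ccc(Cl)c(Cl)c2)cc1`: 19000 nM

Compound 3, at 19000 nM, sits close to both of the others, with a 1.4-fold higher number from compound 1 to compound 3 (0.13 log units; within the scatter) and a 1.9-fold lower number from compound 2 to compound 3 (0.29 log units; within the scatter). Only compound 1 and compound 2 stand clearly apart, with a 2.6-fold higher number from compound 1 to compound 2 (0.42 log units; beyond the scatter).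

Compound 4 `CCc1ccc(C[C@H]2COC(=O)[C@@H]2Cc2ccc(Cl)c(Cl)c2)cc1` differs from compound 3 by one small change, (methyl in place of hydrogen on a saturated chain carbon bound to an aromatic carbon). This is methyl in place of hydrogen on a saturated chain carbon bound to an aromatic carbon, so 4-methylphenyl becomes 4-ethylphenyl.

Among the compounds with values here, no measured step makes exactly this change. The closest one is methyl in place of methoxy on an aromatic carbon, which gave a 1.9-fold lower number from compound 2 to compound 3 (0.29 log units; within the scatter). Even the larger exchange of the whole 3-fluorophenyl for 4-methylphenyl gave only a 1.4-fold higher number from compound 1 to compound 3 (0.13 log units; within the scatter). The extension to ethyl is smaller still, so no shift beyond the scatter is expected in this assay.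

The expected step is a 1.1-fold higher number from compound 3 to compound 4 (0.02 log units; within the scatter). For compound 4 the estimated value is 20000 nM, with an expected range from 10000 nM to 38000 nM.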

Compound 4, half-maximal effective concentration: 16000 nM
Compound 4: the middle estimate sits 1.3-fold (0.10 log units) above what was measured; the range from low to high includes it.
By their numbers in this assay, from the lowest: compounds 1, 4, 3 and 2 (each within the scatter of the next, the first and the last beyond it).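

In this assay the step from 4-methylphenyl to 4-ethylphenyl stays within the scatter (a 1.2-fold lower number from compound 3 to compound 4 (0.07 log units; within the scatter)), so one added carbon at this spot gives no readable change. Compound 4 also stands level with the 3-fluorophenyl analogue (a 1.1-fold higher number from compound 1 to compound 4 (0.06 log units; within the scatter)), but ethyl in place of methoxy gives a modest step beyond the scatter (a 2.3-fold lower number from compound 2 to compound 4 (0.36 log units; beyond the scatter)), which leaves compound 2 apart from compound 1 and compound 4 but not from compound 3. No supporting measurement accounts for these differences.

Going by these compounds, it remains open whether a longer chain such as propyl or butyl in place of the ethyl would keep the number where it is. An amine or a carboxylic acid at that spot is equally untested by the compounds shown here.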